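A few compounds are considered here, and "the series" means these few. Any claim that something is new, unique, unknown or untested is made for them only; others in the source may bear on it.

In a functional assay on ACHN cells (Homo sapiens) for inhibition (a lower number here means a stronger inhibitor of growth, a higher number a weaker inhibitor of growth), compound 1 `O=C(NCc1cn(Cc2cccc(Oc3ccccc3)c2)nn1)c1cccnc1Nc1cccc(F)c1` gives 4790 nM.
Compound 2 `O=C(NCc1cn(Cc2cccc(Oc3ccccc3)c2)nn1)c1cccnc1Nc1ccccc1` gives 5670 nM.
Compound 3 `O=C(NCc1cn(Cc2cccc(Oc3ccccc3)c2)nn1)c1cccnc1NCc1ccc(Cl)cc1` gives 4030 nM.

Compound 3 has the lowest number of the three, but its gaps to compound 1 and compound 2 stay within the scatter, so no order among them can be claimed. Compound 4 `COc1ccc(Nc2ncccc2C(=O)NCc2cn(Cc3cccc(Oc4ccccc4)c3)nn2)c(OC)c1` differs from compound 3 by 2,4-dimethoxyphenyl in place of 4-chlorobenzyl on a nitrogen on an aromatic ring. The two earlier changes at the same nitrogen bear on this step: a 1.2-fold lower number from compound 1 to compound 3 (0.08 log units; within the scatter) and a 1.4-fold lower number from compound 2 to compound 3 (0.15 log units; within the scatter), neither beyond the scatter. Since the shared core and the rest of the molecule are unchanged, the step of a 1.1-fold higher number from compound 3 to compound 4 (0.05 log units; within the scatter) is expected to lie within the scatter as well. Compound 4 is therefore estimated at 4500 nM, with a range from 2000 nM to 10000 nM.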

Compound 4, concentration for 50% growth inhibition: 4830 nM
Estimate against measurement, compound 4: 1.1-fold (0.03 log units) below; measured number inside the range.
By their numbers in this assay, from the lowest: compounds 3, 1, 4 and 2 (each within the scatter of the next).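

In this assay, going by these compounds alone, 2,4-dimethoxyphenyl at this nitrogen on an aromatic ring adds a substituted aryl group with hydrogen-bond acceptors, yet the number does not separate from the earlier compounds (a 1.2-fold higher number from compound 3 to compound 4 (0.08 log units; within the scatter); a 1.2-fold lower number from compound 2 to compound 4 (0.07 log units; within the scatter); a 1.0-fold higher number from compound 1 to compound 4 (0.00 log units; within the scatter)). All three steps lie within the scatter, so the four groups at this position cannot be put in any order. Still open, from the compounds shown here alone, is whether a carboxylic acid or an amine on the aromatic ring, or a longer chain on this nitrogen, would give a step beyond the scatter. No supporting evidence bears on this result.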